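Ring substituent variation on the shared core

A few compounds are considered here, and "the series" means these few. Any claim that something is new, unique, unknown or untested is made for them only; others in the source may bear on it.

Measured so far:
compound 1 `CS(=O)(=O)NNc1nonc1/C(=N/O)Nc1ccc(F)c(Br)c1` gives 609 nM
compound 2 `[O-][S+]1CC(Nc2nonc2/C(=N/O)Nc2ccc(F)c(Br)c2)C1` gives 212 nM

In an assay on isolated protein for inhibition of Indoleamine 2,3-dioxygenase 1 (Homo sapiens), read by fluorescence, with a stated time of 60 min (a higher number here means a weaker inhibitor, a lower number a stronger inhibitor), compound 2 holds the lower of the two numbers, the step being a 2.9-fold lower number from compound 1 to compound 2 (0.46 log units; beyond the scatter). Compound 3 `N=S1(=O)CC(Nc2nonc2/C(=N/O)Nc2ccc(F)c(Br)c2)C1` carries a group of 6 heavy atoms (3 carbon, 1 nitrogen, 1 oxygen, 1 sulfur; one four-membered non-aromatic ring with 1 hetero atom) in place of a group of 5 heavy atoms (3 carbon, 1 oxygen, 1 sulfur; one four-membered non-aromatic ring with 1 hetero atom), on a nitrogen on an aromatic ring. Going by the values given here, no measured step covers this particular change: the single step recorded, a 2.9-fold lower number from compound 1 to compound 2 (0.46 log units; beyond the scatter), exchanged a different group on the same nitrogen and cannot be transferred. The expected step is therefore a 1.1-fold lower number from compound 2 to compound 3 (0.03 log units; within the scatter), not beyond the scatter. For compound 3 the estimate in this assay is 200 nM, with a range from 80 nM to 500 nM.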

Compound 3, half-maximal inhibitory concentration: 208 nM
Beside the measured number, compound 3's estimate is 1.0-fold (0.02 log units) below it, within the range that was stated.
By their numbers in this assay, from the lowest: compounds 3 and 2 (each within the scatter of the next); then compound 1.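

In this assay, the four-membered non-aromatic ring group on this nitrogen accepts the added nitrogen, with its hydrogen-bond donor, without a step beyond the scatter (a 1.0-fold lower number from compound 2 to compound 3 (0.01 log units; within the scatter)). Both groups with this ring stand apart from the ringless group of compound 1, and the new group repeats that separation (a 2.9-fold lower number from compound 1 to compound 3 (0.47 log units; beyond the scatter)). No supporting data explain this result. On these data alone, whether an amine or a carboxylic acid on the same ring, or a longer chain on this nitrogen, would keep this level stays open.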